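Aryl swap on the ring nitrogen of the shared core

The compounds below may be only part of what the source reports. "The series", "measured", "known", "first", "only" and "open" are said of these compounds alone.

Measured compounds:
- compound 1 `COc1cc2c(Oc3ccc(NC(=O)c4nn(-c5cccc(F)c5)c(=O)c5ccccc45)cc3F)ccnc2cc1OCCCN1CCCC1`: 190 nM
- compound 2 `COc1cc2c(Oc3ccc(NC(=O)c4nn(-c5ccccc5F)c(=O)c5ccccc45)cc3F)ccnc2cc1OCCCN1CCCC1`: 230 nM

Both numbers come from a functional assay on NCI-H460 cells (Homo sapiens) for cytotoxicity, read by MTT assay, with a stated time of 72 h; a higher number here means a weaker inhibitor, a lower number a stronger inhibitor. Going by the values given here, compound 2 stands at the higher of the two numbers, but the only measured step, a 1.2-fold higher number from compound 1 to compound 2 (0.08 log units; within the scatter), is within the scatter, so the two compounds cannot be told apart on these data.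

Compound 3 `COc1cc2c(Oc3ccc(NC(=O)c4nn(-c5ccc(Br)cc5)c(=O)c5ccccc45)cc3F)ccnc2cc1OCCCN1CCCC1` is not yet measured. It differs from compound 2 in one place: 4-bromophenyl in place of 2-fluorophenyl on an aromatic nitrogen. Among the compounds with values here, the sole step that bears on it is the fluorine move from compound 1 to compound 2, which produced no change beyond the scatter. Within the data shown here, no measured pair tests a bromine or a para substituent, so the expectation rests on that single small step alone. The expected outcome is no step beyond the scatter: compound 3 is estimated at 220 nM, with a range of 90 nM to 550 nM, corresponding to an expected step of a 1.0-fold lower number from compound 2 to compound 3 (0.02 log units; within the scatter).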

Compound 3, half-maximal inhibitory concentration: 180 nM
For compound 3 the middle estimate is 1.2-fold (0.09 log units) above the measured one; the range from low to high includes it.
By their numbers in this assay, from the lowest: compounds 3, 1 and 2 (each within the scatter of the next).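

In this assay the aryl group on the ring nitrogen now takes a change larger than a fluorine move: 4-bromophenyl in place of 2-fluorophenyl gives (a 1.3-fold lower number from compound 2 to compound 3 (0.11 log units; within the scatter)), and 4-bromophenyl in place of 3-fluorophenyl gives (a 1.1-fold lower number from compound 1 to compound 3 (0.02 log units; within the scatter)). Both steps stay within the scatter, so a different halogen at a different ring position has not separated any of the three compounds, although the swap from compound 2 changes halogen and position together. No measurement is available to explain this flat result.

Still open, as far as these compounds go, is whether any group at this position moves the number beyond the scatter, for example an unsubstituted phenyl, an aminophenyl or a carboxyphenyl. From the compounds shown here alone, replacing the aryl ring with a simple methyl group also remains untested here.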